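The source may hold more compounds than are shown below. What is called first, only, known or untested is meant among the compounds shown, and "the series" means these compounds.

In a functional assay on DU-145 cells (Homo sapiens) for cytotoxicity, read by sulforhodamine B assay, with a stated time of 48 h (on this read-out lower numbers stand for stronger inhibition and higher numbers for weaker inhibition), compound 1 (`C[C@H]1CC[C@@H]2[C@@H](OC(=O)[C@]23CC(c2ccc(Cl)cc2)=NO3)[C@]2(C)C(=O)C=C[C@@]12O`) gives 43000 nM and compound 2 (`C[C@H]1CC[C@@H]2[C@@H](OC(=O)[C@]23CC(c2ccc(N(C)C)cc2)=NO3)[C@]2(C)C(=O)C=C[C@@]12O`) gives 4500 nM, while compound 3 (`C[C@H]1CC[C@@H]2[C@@H](OC(=O)[C@]23CC(c2cccc([N+](=O)[O-])c2)=NO3)[C@]2(C)C(=O)C=C[C@@]12O`) gives 51000 nM and so stands level with compound 1 at the weak end of this small set. Compound 4 (`Cc1ccccc1C1=NO[C@]2(C1)C(=O)O[C@@H]1[C@H]2CC[C@H](C)[C@]2(O)C=CC(=O)[C@@]12C`) carries 2-methylphenyl in place of 3-nitrophenyl on a carbon with a double bond to nitrogen. Both large moves so far (a 9.6-fold lower number from compound 1 to compound 2 (0.98 log units; beyond the scatter); an 11-fold higher number from compound 2 to compound 3 (1.05 log units; beyond the scatter)) involve the dimethylamino group, and compound 4 has no such group. Between the two compounds without it, the number barely moved (a 1.2-fold higher number from compound 1 to compound 3 (0.07 log units; within the scatter)). Within the data shown here, no measured compound has 2-methylphenyl, but a small step within the scatter is expected (a 1.5-fold lower number from compound 3 to compound 4 (0.16 log units; within the scatter)). For compound 4 the estimated value is 35000 nM (expected range 10000 nM to 90000 nM).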

Compound 4, half-maximal inhibitory concentration: 12000 nM
For compound 4 the middle estimate is 2.9-fold (0.46 log units) above the measured one; measured number inside the range.
By their numbers in this assay, from the lowest: compound 2; then compound 4; then compounds 1 and 3 (each within the scatter of the next).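

At this position, a phenyl group without dimethylamino can also move the number beyond the scatter in this assay: 2-methylphenyl gives a 4.3-fold lower number from compound 3 to compound 4 (0.63 log units; beyond the scatter) and a 3.6-fold lower number from compound 1 to compound 4 (0.55 log units; beyond the scatter). The 4-(dimethylamino)phenyl group still gives the lowest number, with a 2.7-fold higher number from compound 2 to compound 4 (0.43 log units; beyond the scatter). No measured evidence here explains these steps. A 4-methylphenyl group would help show whether the methyl group itself or its place on the phenyl ring matters, and the compounds shown leave that open.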